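Swapping 4-fluorophenoxy for 1H-pyrazol-1-yl: expected solubility

A few compounds are considered here, and "the series" means these few. Any claim that something is new, unique, unknown or untested is made for them only; others in the source may bear on it.

Measured so far in a physicochemical assay for solubility, using the shake flask method, in simulated intestinal fluid, measured as kinetic solubility, with a stated time of 2 h, at 25 degrees C, at pH 6.5; on this read-out higher numbers stand for higher solubility and lower numbers for lower solubility:
- compound 1 `Cc1noc(-c2nc(C)c3c(c2N)C(=O)N(Cc2ccc(-c4ccncc4)cc2)C3=O)n1` gives < 5000 nM as a limit of the assay
- compound 2 `Cc1noc(-c2nc(C)c3c(c2N)C(=O)N(Cc2ccc(Oc4ccc(F)cc4)cc2)C3=O)n1` gives 23800 nM as a number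

Going by the values given here, compound 2 at 23800 nM holds the only number in this assay so far. Not yet measured is compound 3 `Cc1noc(-c2nc(C)c3c(c2N)C(=O)N(Cc2ccc(-n4cccn4)cc2)C3=O)n1` with 1H-pyrazol-1-yl in place of 4-fluorophenoxy on an aromatic carbon as its change. Among the compounds with values here, the one measured step bearing on this is an at least 4.7-fold higher number from compound 1 to compound 2 (0.67 log units; beyond the scatter) with 4-fluorophenoxy in place of pyridin-4-yl on an aromatic carbon. Compound 3 also loses 4-fluorophenoxy in favour of an aromatic ring containing nitrogen, so a move back down is expected. The expected change is a 3.4-fold lower number from compound 2 to compound 3 (0.53 log units; beyond the scatter) in this assay as a drop beyond the scatter. The estimate for compound 3 is 7000 nM with an expected range from 2500 nM to 24000 nM in this read-out.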

Compound 3, solubility: < 5000 nM
Compound 3 was reported as a limit; the forecaster's own chance of this, stated with the estimate: 35%; middle value at least 1.4-fold (0.14 log units) from the limit.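

In this assay, 1H-pyrazol-1-yl in place of 4-fluorophenoxy on an aromatic carbon gives an at least 4.7-fold lower number from compound 2 to compound 3 (0.67 log units; beyond the scatter), so the loss at this position is not specific to the pyridin-4-yl of compound 1. The step between compound 1 and compound 3 cannot be read, as both values are limits. Further differences at the low end of this read-out are hidden: the limit of < 5000 nM in this assay, at which 2 of the 3 values shown sit.

Still open, going by these compounds, is whether the ether oxygen, the fluorine or the carbon-only ring matters in compound 2. A plain phenoxy, a benzyloxy or a morpholine at this position would help separate these.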